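Replacing hydroxymethyl in compound 2: working notes

The source may report more compounds than this note shows. Statements on the series, on what has been measured and on what is new or still open speak of the compounds shown alone.

Measured in a functional assay on LNCaP cells (Homo sapiens) for antiproliferative activity, read by MTT assay, with a stated time of 3 days; a lower number here means a stronger inhibitor, a higher number a weaker inhibitor:
- compound 1 `CCCS(=O)(=O)Nc1ccc(-c2cc(=O)c3c(O)cc(OC)c(OC(C)C)c3o2)cc1`: 30500 nM
- compound 2 `COc1cc(O)c2c(=O)cc(-c3ccc(N4CC(C)NC(C)C4)cc3)oc2c1OCCO`: 3800 nM

Compound 2 holds the lower of the two numbers, and its gap to compound 1 lies beyond the scatter. The next analogue, compound 3 `COc1cc(O)c2c(=O)cc(-c3ccc(N4CC(C)NC(C)C4)cc3)oc2c1OCC(OC)OC`, keeps compound 2 unchanged except for one group: dimethoxymethyl in place of hydroxymethyl on a saturated chain carbon bound to an oxygen on an aromatic ring.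

Within the data shown here, no measured pair isolates this change. The expectation rests only on compound 2 at 3800 nM and on the structural change itself, and the range is kept wide. In this assay, a small move toward weaker inhibition is expected, close to the scatter. The estimated step is a 1.6-fold higher number from compound 2 to compound 3 (0.20 log units; within the scatter). Compound 3 is expected at 6000 nM, with an estimated range from 2000 nM to 18000 nM.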

Compound 3, half-maximal inhibitory concentration: 5300 nM
The estimate for compound 3 lay 1.1-fold (0.05 log units) above the measured number; the measured number falls inside the stated range.
By their numbers in this assay, from the lowest: compounds 2 and 3 (each within the scatter of the next); then compound 1.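

In this assay, replacing hydroxymethyl with dimethoxymethyl on this saturated chain carbon gives a 1.4-fold higher number from compound 2 to compound 3 (0.14 log units; within the scatter), so this pair shows no change beyond the scatter. The group's hydrogen-bond donors go from 1 to 0 and its heavy atoms from 2 to 5, yet compound 3 stays within the scatter of compound 2, which means that this one swap gives no sign that the hydroxyl is needed for the read-out in these cells. Nothing available explains this result or links it to any property of either group.

As far as these compounds go, whether this holds for an amine, a carboxylic acid or a longer chain at the same place remains open. Compound 1 differs from both compounds in more than one place, so it cannot show how the 2-hydroxyethoxy or 2,2-dimethoxyethoxy group alone acts on another core.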